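A few compounds are considered here, and "the series" means these few. Any claim that something is new, unique, unknown or untested is made for them only; others in the source may bear on it.

Measured so far in an in vivo ADME assay on the whole organism (plasma) for pharmacokinetics, with Canis familiaris (Canis lupus familiaris) as the target, at a dose of 1 mg/kg by the oral route; on this read-out higher numbers stand for higher exposure at the dose given and lower numbers for lower exposure:
Compound 1 `Cc1cnc(NCC2(c3ccc(F)cc3)CC2)c(=O)n1CC(=O)NCc1ccc2[nH]nc(N)c2c1` gives 1850 nM.
Compound 2 `Cc1cnc(NCC2(c3ccc(F)cc3)CC2)c(=O)n1CC(=O)NCc1ccc2c(N)noc2c1` gives 1780 nM.

Compound 1 holds the top number of the two, yet the step of a 1.0-fold lower number from compound 1 to compound 2 (0.02 log units; within the scatter) lies within the scatter, so the two compounds are not truly separated. Compound 3 `COc1ccc(C2(CNc3ncc(C)n(CC(=O)NCc4ccc5[nH]nc(N)c5c4)c3=O)CC2)cc1` differs from compound 1 by methoxy in place of fluoro on an aromatic carbon. For the measured compounds named here, no measured step touches this position, and the only recorded step concerned a different part of the molecule and barely moved the number. A change beyond the scatter is therefore not expected in either direction. Compound 3 is estimated at 1500 nM, with a range from 600 nM to 4000 nM, meaning an expected step of a 1.2-fold lower number from compound 1 to compound 3 (0.09 log units; within the scatter).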

Compound 3, maximal plasma concentration in the Canis familiaris assay: 2810 nM
Beside the measured number, compound 3's estimate is 1.9-fold (0.27 log units) below it, and the stated range covers the measured number.
By their numbers in the Canis familiaris assay, from the lowest: compounds 2, 1 and 3 (each within the scatter of the next).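

In the Canis familiaris assay compound 1 gives 1850 nM and compound 3 gives 2810 nM, so methoxy in place of fluoro on this aromatic carbon, para to a large group, does not separate the two (a 1.5-fold higher number from compound 1 to compound 3 (0.18 log units; within the scatter)), and this position accepts either group without a change beyond the scatter. In a physicochemical assay for acid dissociation, compound 1 gives 3.6 and compound 3 gives 3.6, so the swap leaves this reading as it was (no change at the digits printed from compound 1 to compound 3 (within the scatter)). Nothing available explains these readings.

Still open, as far as these compounds go, is whether an amine, a carboxylic acid or a longer chain such as butoxy at this position would move exposure beyond the scatter. Also open, from the compounds shown here alone, is whether methoxy behaves the same way on the core of compound 2.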